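The source may hold more compounds than are shown below. What is called first, only, known or untested is meant among the compounds shown, and "the series" means these compounds.

The series shares the core of compound 1 `COc1cc2nnc(C(N)=O)c(Nc3ccc(F)cc3F)c2cc1OC`, which in a physicochemical assay for solubility (on this read-out higher numbers stand for higher solubility and lower numbers for lower solubility), gives 3000 nM. Compound 2 `COc1cc2nnc(C(N)=O)c(Nc3cc(C)ccc3F)c2cc1OC` carries a different aryl group on the anilino nitrogen. In this assay compound 2 reaches only a limit of the assay, < 1000 nM, and not a number. Within the data shown here, the single measured step in the set is an at least 3.0-fold lower number from compound 1 to compound 2 (0.47 log units; beyond the scatter); because one of the two values sits at the limit of < 1000 nM in this assay, at which 1 of the 2 values shown sits, the true size of that step is open. Compound 3 `COc1cc2nnc(C(N)=O)c(Nc3cc(C)ccc3F)c2cc1N1CCN(C)CC1` differs from compound 2 at the methoxy-bearing part of the core: 4-methylpiperazin-1-yl in place of methoxy on an aromatic carbon. Among the measured compounds shown here, this change has no counterpart among the measured steps; the only step measured concerns the aryl on the nitrogen and says nothing about the position altered here. For the measured compounds named here, no measured step therefore sets the size or direction of the change to be expected in this assay. On the numbers alone compound 3 is estimated at 5000 nM, with a range from 800 nM to 30000 nM, which would mean an expected at least 5.0-fold higher number from compound 2 to compound 3 (0.69 log units; beyond the scatter), with a fair chance that again only a limit is reported.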

Compound 3, solubility: 22000 nM
Compound 3: middle estimate off by 4.4-fold (0.64 log units), on the low side; the measured number falls inside the stated range.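

In this assay, the aromatic carbon ortho to a methoxy group proves highly responsive to substitution: an at least 22-fold higher number from compound 2 to compound 3 (1.34 log units; beyond the scatter) follows the exchange of methoxy for 4-methylpiperazin-1-yl. Among these compounds, this is the first measured change at this position, as the earlier step concerned only the aryl group on the nitrogen, and the 2-fluoro-5-methylphenyl group stays the same across this step. Compound 2 stands at a limit of the assay and not at a number, so the step gives only a minimum and its true size stays open: the limit of < 1000 nM in this assay, at which 1 of the 3 values shown sits.

Open is which part of the 4-methylpiperazin-1-yl group carries the step, since the compounds shown do not say whether a morpholine ring, an unsubstituted piperazine or an open-chain dimethylamino group at this carbon would give a similar number in this assay. Also open, as far as these compounds go, is whether the same exchange holds with the 2,4-difluorophenyl group of compound 1, which gives 3000 nM, a starting number from which the full size of a step could be read.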